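Compound 3 to compound 4: swapping the bromo-methoxy aryl group

This account rests on a few compounds, and the source may have more. Where it says the series, first, only, none or still open, it means among the compounds named here.

Measured so far in a functional assay on DU-145 cells (Homo sapiens) for cytotoxicity; a lower number here means a stronger inhibitor of growth, a higher number a weaker inhibitor of growth
- compound 1 `COc1ccc(C2=C(c3cc(OC)c(OC)c(OC)c3)CC3CCCN3C2=O)cc1O` gives > 100000 nM (a limit, not a number)
- compound 2 `COc1ccc(C2=C(c3ccc(SC)cc3)CC3CCCN3C2=O)cc1OC(=O)C1CCCN1C(=O)OC(C)(C)C` gives 5000 nM
- compound 3 `COc1ccc(C2=C(c3ccc(SC)cc3)CC3CCCN3C2=O)cc1Br` gives 900 nM

Compound 3 holds the lower of the two actual numbers: compound 2 reads 5000 nM and compound 3 reads 900 nM with a gap beyond the usual scatter.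

The next compound is compound 4 `CSc1ccc(C2=C(c3ccc(C)c(C)c3)C(=O)N3CCCC3C2)cc1` with the change 3,4-dimethylphenyl in place of 3-bromo-4-methoxyphenyl on a double-bonded ring carbon to be read as follows: 3,4-dimethylphenyl in place of 3-bromo-4-methoxyphenyl on a double-bonded ring carbon, while the 4-(methylsulfanyl)phenyl group stays.

Going by the values given here, no measured pair isolates this change, so the expectation is loose. In this assay a move to a higher number is expected, of a size probably beyond the scatter, although a result within the scatter remains possible. Among the compounds with values here, the expectation starts from compound 3 with 900 nM as the lowest number so far, which leaves upward as the likelier direction. It also takes in compound 2 with 5000 nM as the other number carrying the 4-(methylsulfanyl)phenyl group.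

The estimate expects a step of a 3.3-fold higher number from compound 3 to compound 4 (0.52 log units; beyond the scatter) in this direction.

For compound 4 the expected value is 3000 nM (estimated range 600 nM to 20000 nM).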

Compound 4, concentration for 50% growth inhibition: 500 nM
Compound 4: the middle estimate sits 6.0-fold (0.78 log units) above what was measured, outside the stated range (below it).
By their numbers in this assay, from the lowest: compounds 4 and 3 (each within the scatter of the next); then compound 2. At a limit, above all of these: compound 1.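

In this assay, going by these compounds alone, a 1.8-fold lower number from compound 3 to compound 4 (0.26 log units; within the scatter), which gives the first one-place comparison at this double-bonded ring carbon, with the 4-(methylsulfanyl)phenyl group held constant. Compounds 3 and 4 read alike within the usual scatter, so in this pair neither the bromine nor the methoxy oxygen of the 3-bromo-4-methoxyphenyl group is needed to keep growth inhibition at this level, and an all-carbon 3,4-dimethylphenyl group serves equally well in this assay. Nothing at hand gives a cause for this outcome, and the limit recorded for compound 1 does not bear on this pair.

Both substituents on the aryl group change together, so the pair cannot assign any contribution to the bromine, the methoxy group or either methyl group taken alone, and it says nothing about whether the same swap would read alike with another group in place of the 4-(methylsulfanyl)phenyl group. Also open is how an aryl group carrying an amine or a carboxylic acid would read at this ring carbon, since every aryl group shown here bears only neutral substituents.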